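A few compounds are considered here, and "the series" means these few. Any claim that something is new, unique, unknown or untested is made for them only; others in the source may bear on it.

Measured in an ADME assay on microsomes from liver (Homo sapiens) for metabolic stability; a higher number here means faster removal of the compound, a lower number slower removal:
- compound 1 `Cc1ccc(C(=O)Nc2cn3ncnc3c(CN3CCN(C(=O)C(C)C)[C@@H](C)C3)c2C)cn1`: 240 mL.min-1.g-1
- compound 2 `Cc1ccc(C(=O)Nc2cn3ncnc3c(CN3CCN(C(=O)C4CCCC4)[C@@H](C)C3)c2C)cn1`: 32 mL.min-1.g-1

Of the two, compound 2 stands lowest at 32 mL.min-1.g-1. Compound 3 `Cc1ccc(C(=O)Nc2cn3ncnc3c(CN3CCN(C(=O)C4CCC(F)(F)C4)[C@@H](C)C3)c2C)cn1` departs from it as follows: 3,3-difluorocyclopentyl in place of cyclopentyl on a carbonyl carbon. Among the compounds with values here, the one measured step bearing on this place on a carbonyl carbon is a 7.5-fold lower number from compound 1 to compound 2 (0.88 log units; beyond the scatter), which lies beyond the scatter. It shows that this group can move the number in this assay, but it involved no fluorine and so gives no direction here. The expected change is small and slightly downward, not beyond the scatter: a 1.3-fold lower number from compound 2 to compound 3 (0.12 log units; within the scatter). For compound 3 the estimated value is 24 mL.min-1.g-1, with an expected range from 10 mL.min-1.g-1 to 60 mL.min-1.g-1.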

Compound 3, intrinsic clearance in microsomes: < 10 mL.min-1.g-1
Compound 3: a limit, no number (the forecaster's own chance of this, stated with the estimate: 3%); middle value at least 2.4-fold (0.38 log units) from the limit.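

In this assay, 3,3-difluorocyclopentyl in place of cyclopentyl on a carbonyl carbon gives an at least 3.2-fold lower number from compound 2 to compound 3 (0.50 log units; beyond the scatter), so the number at this place responds to fluorine on the ring as well as to the change from isopropyl to a ring. Measured from the isopropyl amide, the change gives an at least 24-fold lower number from compound 1 to compound 3 (1.38 log units; beyond the scatter). The reading for compound 3 is a limit and not a number: the limit of < 10 mL.min-1.g-1 in this assay, at which 1 of the 3 values shown sits.

On these data alone, how far compound 3 lies beyond that limit remains open, so the full size of both steps is unknown. Also open, as far as these compounds go, is whether a cyclohexyl or tetrahydropyranyl group on this carbonyl carbon would bring the number down as far.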